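Two Limits and a Halogen-Methyl Swap

The source may report more compounds than this note shows. Statements on the series, on what has been measured and on what is new or still open speak of the compounds shown alone.

- Compound 1 `Nc1nc(NCCNc2ncc(-c3ncc[nH]3)c(-c3ccc(Br)cc3Cl)n2)ccc1[N+](=O)[O-]`: > 0.5 h
- Compound 2 `Cc1ccc(-c2nc(NCCNc3ccc([N+](=O)[O-])c(N)n3)ncc2-c2ncc[nH]2)c(Br)c1`: > 0.5 h

In an ADME assay on microsomes from liver (Canis lupus familiaris) for metabolic stability (on this read-out lower numbers stand for a shorter-lived compound and higher numbers for a longer-lived compound), compound 2 gives > 0.5 h, which is a limit of the assay and not a number. Compound 1 also gives a limit, > 0.5 h. The two compounds therefore share one reading: the limit of > 0.5 h in this assay, at which 2 of the 2 values shown sit.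

Compound 3 `Cc1cc(Cl)ccc1-c1nc(NCCNc2ccc([N+](=O)[O-])c(N)n2)ncc1-c1ncc[nH]1` carries 4-chloro-2-methylphenyl in place of 2-bromo-4-methylphenyl on an aromatic carbon.

Among the measured compounds shown here, only one measured step swaps a substituted phenyl group in this way: a step that the two limits leave unreadable from compound 1 to compound 2. It gives no size to carry over, so no step beyond the usual scatter is expected in this assay, and no direction can be called. The estimated step is a step that the limit leaves unreadable from compound 2 to compound 3. For compound 3 the expected half-life is 0.7 h, with an estimated range of 0.4 h to 1.4 h. A further limit rather than a number is the likeliest report.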

Compound 3, half-life: > 0.5 h
Compound 3 ended at the assay's limit; the forecaster's own chance of this, stated with the estimate: 80%; the middle value does not contradict the limit.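

Compound 1, compound 2 and compound 3 cannot be told apart in this assay, and no step among them can be read, since all three share one reading: the limit of > 0.5 h in this assay, at which 3 of the 3 values shown sit.

As far as these compounds go, how long each compound actually lasts, and whether swapping the substituted phenyl group matters at all, stays open.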